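Two Chlorines Added to the Aryl Amine of Compound 1

A few compounds are considered here, and "the series" means these few. Any claim that something is new, unique, unknown or untested is made for them only; others in the source may bear on it.

Of the compounds shown here, three built on one shared core have been measured in an assay on COS-7 cells for agonist activity at Free fatty acid receptor 1 (Homo sapiens), read by scintillation counting and inositol phosphate accumulation, with a stated time of 90 min; a lower number here means that less compound is needed, a higher number that more compound is needed for the effect. Compound 1 `Cc1ccc(Nc2nc(N)nc(COc3ccc4c(C)cc(=O)oc4c3)n2)cc1` gives 1790 nM, the highest of the three numbers. Compound 2 `Cc1cc(=O)oc2cc(OCc3nc(N)nc(Nc4ccc5c(c4)COC5)n3)ccc12` gives 1330 nM, and a 1.3-fold lower number from compound 1 to compound 2 (0.13 log units; within the scatter), so these two cannot be told apart. Compound 3 `Cc1ccc(Nc2nc(N)nc(COc3ccc4c(C)cc(=O)oc4c3)n2)cc1C` gives 210 nM; here an 8.5-fold lower number from compound 1 to compound 3 (0.93 log units; beyond the scatter), and a 6.3-fold lower number from compound 2 to compound 3 (0.80 log units; beyond the scatter).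

Compound 4 `Cc1c(Cl)cc(Nc2nc(N)nc(COc3ccc4c(C)cc(=O)oc4c3)n2)cc1Cl` has not yet been measured. Relative to compound 1 the change is 3,5-dichloro-4-methylphenyl in place of 4-methylphenyl on a nitrogen on an aromatic ring. Going by the values given here, the step that bears on it most is the one from compound 1 to compound 3, where a substituent added to the same aromatic ring on the same nitrogen lowered the number beyond the scatter, while the swap of that ring in compound 2 changed little. Two chlorines on that ring are therefore expected to lower the number as well, roughly a 6.4-fold lower number from compound 1 to compound 4 (0.81 log units; beyond the scatter). Compound 4 is estimated at 280 nM, within a range of 80 nM to 900 nM.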

Compound 4, half-maximal effective concentration: 600 nM
Estimate against measurement, compound 4: 2.1-fold (0.33 log units) below; the range from low to high includes it.
By their numbers in this assay, from the lowest: compound 3; then compound 4; then compounds 2 and 1 (each within the scatter of the next).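

In this assay, two chlorines added to the 4-methylphenyl on the nitrogen also lower the number (a 3.0-fold lower number from compound 1 to compound 4 (0.47 log units; beyond the scatter)), so among the compounds shown a change of this ring that adds atoms is not limited to a methyl in lowering it. Going by these compounds alone, the gain is smaller than with 3,4-dimethylphenyl (a 2.9-fold higher number from compound 3 to compound 4 (0.46 log units; beyond the scatter)), yet 3,5-dichloro-4-methylphenyl still gives a lower number than the group on compound 2 (a 2.2-fold lower number from compound 2 to compound 4 (0.35 log units; beyond the scatter)), so the ring's substituents separate compounds that the first pair of ring changes did not. No measurement at hand explains why one methyl outdoes two chlorines.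

From the compounds shown here alone, it remains open whether a single chlorine on this ring would land nearer compound 3 or compound 4. Also open, going by these compounds, is how a methoxy group, a trifluoromethyl group or an amine on the same ring would compare.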